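The source may report more compounds than this note shows. Statements on the series, on what has been measured and on what is new or still open speak of the compounds shown alone.

In an assay on isolated protein for inhibition of Leucine-rich repeat serine/threonine-protein kinase 2 variant G2019S (Homo sapiens), read by TR-FRET and LanthaScreen, with stated times of 50 min and 30 min, in the presence of a further agent that is not named here (a lower number here means a stronger inhibitor, a higher number a weaker inhibitor), compound 3 `Cc1nn(C)cc1Nc1nc(N)c2c(C#N)c(N3CCC[C@H]3C)n(C)c2n1` gives 30 nM, close to compound 2 `Cc1n[nH]cc1Nc1nc(N)c2c(C#N)c(N3CCC[C@H]3C)n(C)c2n1`, which gives 27 nM. The step of a 1.1-fold higher number from compound 2 to compound 3 (0.05 log units; within the scatter) lies within the scatter. Compound 1 `Cc1nn(C2CCOC2)cc1Nc1nc(N)c2c(C#N)c(N3CCC[C@H]3C)n(C)c2n1`, which also differs at the aromatic nitrogen, gives 12 nM; 28 nM (2 entries), again within the scatter of compound 3. Compound 4 `Cc1nn(CC2(O)COC2)cc1Nc1nc(N)c2c(C#N)c(N3CCC[C@H]3C)n(C)c2n1` carries 3-hydroxyoxetan-3-yl in place of hydrogen on a saturated chain carbon bound to an aromatic nitrogen. Among the measured compounds shown here, no measured step attaches a group at this saturated chain carbon; the nearest guidance is a 1.1-fold higher number from compound 2 to compound 3 (0.05 log units; within the scatter) together with the several entries of compound 1 in this assay, 12 nM; 28 nM (2 entries), and neither moves beyond the scatter of compound 3. The step of a 1.2-fold lower number from compound 3 to compound 4 (0.08 log units; within the scatter) is therefore expected to be small, with no clear direction. Compound 4 is estimated at 25 nM in this assay, with a range from 10 nM to 60 nM.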

Compound 4, half-maximal inhibitory concentration: 51 nM
Compound 4: middle estimate off by 2.0-fold (0.31 log units), on the low side, within the range that was stated.
By their numbers in this assay, from the lowest: compounds 2, 3 and 4 (each within the scatter of the next).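

In this assay, placing 3-hydroxyoxetan-3-yl on the saturated chain carbon bound to an aromatic nitrogen gives a 1.7-fold higher number from compound 3 to compound 4 (0.23 log units; within the scatter) and, counted from the hydrogen on that nitrogen, the whole (3-hydroxyoxetan-3-yl)methyl group gives a 1.9-fold higher number from compound 2 to compound 4 (0.28 log units; within the scatter) in the same assay. Even this larger group therefore leaves the number within the scatter of both smaller compounds. The separate entries for a different group on that nitrogen show a spread of like size: the several entries of compound 1 in this assay, 12 nM; 28 nM (2 entries).

As far as these compounds go, whether an amine, a carboxylic acid or a longer chain at this position would stay within that scatter remains open. So does the effect of the hydroxy group apart from the oxetane ring.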